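The source may report more compounds than this note shows. Statements on the series, on what has been measured and on what is new or still open speak of the compounds shown alone.

Three measured compounds share one core. Compound 1 is `O=C(Nc1ccccc1)Nc1cccc(Nc2nccc(Nc3ccc4cn[nH]c4c3)n2)c1` and in a functional assay on HepG2 cells (Homo sapiens) for inhibition, read by fluorescence and resazurin assay, with a stated time of 72 h (a higher number here means a weaker inhibitor, a lower number a stronger inhibitor), compound 1 gives 8200 nM. Compound 2 is `Cc1ccc(Nc2nccc(Nc3ccc4cn[nH]c4c3)n2)cc1NC(=O)Nc1ccccc1`; in this assay compound 2 gives 8900 nM. Compound 3 is `Cn1cc2ccc(Nc3ccnc(Nc4cccc(NC(=O)Nc5ccccc5)c4)n3)cc2n1`; in this assay compound 3 gives 12000 nM. The change from compound 1 to compound 2 is methyl in place of hydrogen on an aromatic carbon, and it made a step of a 1.1-fold higher number from compound 1 to compound 2 (0.04 log units; within the scatter). The cores of compound 1 and compound 3 differ by 2-methyl-2H-indazol-6-yl in place of 1H-indazol-6-yl on a nitrogen on an aromatic ring, which made a step of a 1.5-fold higher number from compound 1 to compound 3 (0.17 log units; within the scatter). All three numbers therefore lie within the usual scatter of one another, and no order among them can be read.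

Compound 4, `Cc1c2ccc(Nc3ccnc(Nc4cccc(NC(=O)Nc5ccccc5)c4)n3)cc2nn1C`, is not yet measured. It differs from compound 3 by methyl in place of hydrogen on an aromatic carbon. Going by the values given here, this is the same kind of change as the one from compound 1 to compound 2, but the place is not the same: in compound 2 the methyl sits on a six-membered aromatic ring of carbon only, ortho to a (phenylcarbamoyl)amino group, whereas in compound 4 it sits on a five-membered aromatic ring with 2 nitrogen, part of a fused system of two rings, next to the ring nitrogen.

The step from compound 3 to compound 4 is expected to be a 1.2-fold higher number from compound 3 to compound 4 (0.07 log units; within the scatter), resting on the earlier methyl step of a 1.1-fold higher number from compound 1 to compound 2 (0.04 log units; within the scatter), which stayed within the scatter, with added uncertainty since the ring differs. Compound 4 is expected to give about 14000 nM in this assay. The estimate for compound 4 spans from 6000 nM to 35000 nM.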

Compound 4, half-maximal inhibitory concentration: 2400 nM
For compound 4 the middle estimate is 5.8-fold (0.77 log units) above the measured one, outside the stated range (below it).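

The same methyl change behaved differently on the two cores in this assay: the same change on two cores in this assay, a 1.1-fold higher number (0.04 log units; within the scatter) from compound 1 to compound 2 and a 5.0-fold lower number (0.70 log units; beyond the scatter) from compound 3 to compound 4, 5.4-fold (0.73 log units) apart, beyond the scatter of two such steps. Placed on an aromatic carbon of the five-membered aromatic ring with 2 nitrogen, the methyl made a step of a 5.0-fold lower number from compound 3 to compound 4 (0.70 log units; beyond the scatter) on that core, and the whole swap to 2,3-dimethyl-2H-indazol-6-yl made a step of a 3.4-fold lower number from compound 1 to compound 4 (0.53 log units; beyond the scatter) in the same direction. The size of a methyl step therefore cannot simply be carried from one core to another in this series, but the two steps differ both in the core and in the ring that bears the methyl, so these compounds do not show which of those two differences accounts for the gap, and one pair on each side gives no general rule.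

The compounds shown leave open whether the lower number needs both methyl groups of 2,3-dimethyl-2H-indazol-6-yl or only the one on the aromatic carbon. They also leave open whether an ethyl group or a chlorine atom in that place would give a step of similar size.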